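Swapping the aryl group on the triazole nitrogen

The source may report more compounds than this note shows. Statements on the series, on what has been measured and on what is new or still open speak of the compounds shown alone.

Three compounds share a core and differ only in the aryl group attached to an aromatic nitrogen of that core. Compound 1 `Oc1cc(C(F)(F)F)ccc1-c1nc(-c2ccccc2O)n(-c2ccc(I)cc2)n1` carries a 4-iodophenyl there and, in a functional assay on PC-12 cells (Rattus norvegicus) for cytotoxicity, read by MTT assay, with stated times of 2 h and 24 h, tested at 1 uM (a lower number here means a weaker effect, a higher number a stronger effect of the compound at the concentration tested), compound 1 gives 70.1%. Compound 2 `Oc1cc(C(F)(F)F)ccc1-c1nc(-c2ccccc2O)n(-c2ccccc2F)n1` carries a 2-fluorophenyl and in this assay compound 2 gives 63.4%. Compound 3 `COc1ccccc1-n1nc(-c2ccc(C(F)(F)F)cc2O)nc1-c1ccccc1O` carries a 2-methoxyphenyl and in this assay compound 3 gives 70.7%, the highest of the three numbers, though its gap to each neighbour is within the scatter.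

The measured steps are small: a number 6.7 percentage points lower from compound 1 to compound 2 (within the scatter), a number 0.6 percentage points higher from compound 1 to compound 3 (within the scatter), and a number 7.3 percentage points higher from compound 2 to compound 3 (within the scatter). Every exchange of the aryl group seen so far has therefore left the read-out essentially unchanged.

Compound 4 `Oc1cc(C(F)(F)F)ccc1-c1nc(-c2ccccc2O)n(-c2cccc(C(F)(F)F)c2)n1` is not yet measured. Compared with compound 3 it differs as follows: 3-(trifluoromethyl)phenyl in place of 2-methoxyphenyl on an aromatic nitrogen. Because a number 0.6 percentage points higher from compound 1 to compound 3 (within the scatter) and a number 7.3 percentage points higher from compound 2 to compound 3 (within the scatter) both stayed within the scatter, as did every other swap at this position, the expectation for compound 4 is likewise a step of no real size in this assay, estimated as a number 3.7 percentage points lower from compound 3 to compound 4 (within the scatter). Compound 4 is thus expected to give about 67% in this assay, within a range from 55% to 78%.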

Compound 4, a percentage reported as activity, at one concentration (the size of the read-out at that concentration, not a potency): 71.5%
Beside the measured number, compound 4's estimate is 4.5 percentage points below it; the range from low to high includes it.
By their numbers in this assay, from the lowest: compounds 2, 1, 3 and 4 (each within the scatter of the next).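

The exchange at this position now reaches further than before: 3-(trifluoromethyl)phenyl replaces 2-methoxyphenyl, so a larger group containing fluorine takes the place of one with an oxygen and a hydrogen-bond acceptor, yet this assay shows only a small step (a number 0.8 percentage points higher from compound 3 to compound 4 (within the scatter)). The same holds against the other two aryl groups (a number 8.1 percentage points higher from compound 2 to compound 4 (within the scatter); a number 1.4 percentage points higher from compound 1 to compound 4 (within the scatter)), so 2-fluorophenyl, 2-methoxyphenyl, 4-iodophenyl and 3-(trifluoromethyl)phenyl on the aromatic nitrogen cannot be told apart in this read-out, and none of the four stands out. Nothing available explains why the read-out stays so flat across these four groups, so this remains an observation without a known cause.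

All four compounds keep a phenyl ring on that nitrogen and carry only halogen, trifluoromethyl or methoxy on it, so a phenyl ring bearing an amine or a carboxylic acid, or a longer alkyl chain in place of the ring, could still behave differently. The read-out also comes from a single concentration, so it leaves open whether these compounds would still match one another at other concentrations.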